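Replacing the Arylamino Group with Dipropylamino

The source may report more compounds than this note shows. Statements on the series, on what has been measured and on what is new or still open speak of the compounds shown alone.

compound 1 `Cc1ccc(NC2=CC(=O)c3c(nc4n3[C@H]3OC[C@@H](O)[C@H]3OC4)C2=O)cc1C` — 4090 nM
compound 2 `O=C1C(Nc2ccc(C(F)(F)F)cc2)=CC(=O)c2c1nc1n2[C@H]2OC[C@@H](O)[C@H]2OC1` — 2250 nM
compound 3 `CCOc1ccccc1NC1=CC(=O)c2c(nc3n2[C@H]2OC[C@@H](O)[C@H]2OC3)C1=O` — 4320 nM

Three compounds share one core and differ only in the group on the amine nitrogen. In a functional assay on ECa-109 cells for inhibition, with ECa-109 cell line (Homo sapiens) as the target, read by sulforhodamine B assay (a higher number here means a weaker inhibitor, a lower number a stronger inhibitor), compound 1 gives 4090 nM and stands second highest of the three numbers. Its nearest neighbour is compound 3, which gives 4320 nM, and its furthest is compound 2, which gives 2250 nM. All three measured steps lie within the scatter: a 1.8-fold lower number from compound 1 to compound 2 (0.26 log units; within the scatter), a 1.1-fold higher number from compound 1 to compound 3 (0.02 log units; within the scatter) and a 1.9-fold higher number from compound 2 to compound 3 (0.28 log units; within the scatter). So the three aryl groups tried so far give numbers that cannot be told apart.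

Compound 4 `CCCN(CCC)C1=CC(=O)c2c(nc3n2[C@H]2OC[C@@H](O)[C@H]2OC3)C1=O` departs from this series. Its difference from compound 1 is dipropylamino in place of (3,4-dimethylphenyl)amino on a double-bonded ring carbon. Among the compounds with values here, none of the measured steps swaps an aromatic amine for an open-chain one, so they bear on this change only indirectly: they show that changing the aryl group moved nothing beyond the scatter, but say nothing about removing the ring. The expected step in this assay is therefore of uncertain direction, with no firm reason to expect a move beyond the scatter, though the wider uncertainty widens the range. Compound 4 is expected to give 6000 nM, between 2000 nM and 20000 nM, an expected step of a 1.5-fold higher number from compound 1 to compound 4 (0.17 log units; within the scatter).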

Compound 4, half-maximal inhibitory concentration: > 16000 nM
Compound 4 ended at the assay's limit (the forecaster's own chance of this, stated with the estimate: 10%); middle value at least 2.6-fold (0.42 log units) from the limit.
By their numbers in this assay, from the lowest: compounds 2, 1 and 3 (each within the scatter of the next). At a limit, above all of these: compound 4.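

At the double-bonded ring carbon, dipropylamino in place of (3,4-dimethylphenyl)amino gives an at least 3.9-fold higher number from compound 1 to compound 4 (0.59 log units; beyond the scatter) in this assay, the only step shown that lies beyond the scatter. Compound 4 stands at a limit of the assay, which is not a number, so the step has a lower bound and no known full size: the limit of > 16000 nM in this assay, at which 1 of the 4 values shown sits. Whereas the three aryl groups of compound 1, compound 2 and compound 3 could not be told apart, this position does respond when the arylamino group gives way to an open-chain dialkylamino group.

That single change removes the aromatic ring and the amine's hydrogen-bond donor together, and it also swaps the substituents for two propyl chains, so the compounds shown cannot say which of these differences goes with the weaker number. A secondary amine such as propylamino or cyclohexylamino would keep the donor without the aromatic ring, and N-methyl-N-phenylamino would keep the aromatic ring without the donor, so either could begin to separate the two.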